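Cyano for Fluoro on the Shared Core of Compound 2

The source may report more compounds than this note shows. Statements on the series, on what has been measured and on what is new or still open speak of the compounds shown alone.

Measured compounds in an assay on V79 cells for inhibition of cytochrome P450 11B1, mitochondrial (Homo sapiens), read by HTRF, with a stated time of 1 h; on this read-out lower numbers stand for stronger inhibition and higher numbers for weaker inhibition:
compound 1 `Fc1cc2nc(-c3cccnc3)n(C3CC3)c2cc1F`: 370 nM
compound 2 `Fc1ccc2nc(-c3cccnc3)n(C3CC3)c2c1`: 401 nM
compound 3 `CC(C)(C)n1c(-c2cccnc2)nc2ccc(F)cc21`: > 10000 nM, a limit of the assay rather than a number.

Compound 2 stands at the higher of the two numbers, but a 1.1-fold higher number from compound 1 to compound 2 (0.03 log units; within the scatter), so the two cannot be told apart. Compound 4 `N#Cc1ccc2nc(-c3cccnc3)n(C3CC3)c2c1`, not yet measured, differs from compound 2 by cyano in place of fluoro on an aromatic carbon. The step that bears on this change is a 1.1-fold higher number from compound 1 to compound 2 (0.03 log units; within the scatter), where a fluoro on an aromatic carbon was also exchanged with little effect. The step of an at least 24-fold higher number from compound 2 to compound 3 (1.39 log units; beyond the scatter) concerns the group on the aromatic nitrogen instead and says little here. A small step is therefore expected in this assay. For compound 4 the estimate is 350 nM, between 120 nM and 1100 nM, which is expected to mean a 1.1-fold lower number from compound 2 to compound 4 (0.06 log units; within the scatter).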

Compound 4, half-maximal inhibitory concentration: 374 nM
Compound 4: middle estimate off by 1.1-fold (0.03 log units), on the low side; the measured number falls inside the stated range.
By their numbers in this assay, from the lowest: compounds 1, 4 and 2 (each within the scatter of the next). At a limit, above all of these: compound 3.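

All earlier compounds carry fluoro at this position, so compound 4 gives the first view of a change there. In this assay, cyano, with two heavy atoms and a hydrogen-bond acceptor, replaces fluoro, with one heavy atom, and the result is a 1.1-fold lower number from compound 2 to compound 4 (0.03 log units; within the scatter), so the two groups cannot be told apart. Nothing measured here explains this result. On these data alone, whether an amine, a carboxylic acid or a longer chain at this position would also fall within the scatter stays open. So does whether cyano behaves alike with another group on the aromatic nitrogen.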